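The compounds below may be only part of what the source reports. "The series", "measured", "known", "first", "only" and "open" are said of these compounds alone.

Measured compounds:
- compound 1, `CN1C(=O)C=C(Cl)C1(O)c1ccccc1`: 2500 nM
- compound 2, `CC(C)N1C(=O)C=C(Cl)C1(O)c1ccccc1`: 200 nM
- compound 3, `O=C1C=C(Cl)C(O)(c2ccccc2)N1C1CC1`: 7500 nM

In an assay on cell membranes for displacement of a labelled ligand from Cholecystokinin receptor type A (Rattus norvegicus), read by CCK-8 assay, with a stated time of 2 h (on this read-out lower numbers stand for stronger inhibition and higher numbers for weaker inhibition), compound 3 gives the highest number of the three. Its nearest neighbour is compound 1, and the gap is a 3.0-fold higher number from compound 1 to compound 3 (0.48 log units; beyond the scatter); the furthest is compound 2, with a 38-fold higher number from compound 2 to compound 3 (1.57 log units; beyond the scatter). Compound 4, `O=C1C=C(Cl)C(O)(c2ccccc2)N1C1CCCC1`, is not yet measured. It differs from compound 3 in one place: cyclopentyl in place of cyclopropyl on an amide-type nitrogen in a ring.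

Among the measured compounds shown here, the steps that bear on this change all concern the group on the same amide-type nitrogen. From compound 1 to compound 2 the number fell by a 13-fold lower number from compound 1 to compound 2 (1.10 log units; beyond the scatter), whereas a 3.0-fold higher number from compound 1 to compound 3 (0.48 log units; beyond the scatter) and a 38-fold higher number from compound 2 to compound 3 (1.57 log units; beyond the scatter) went the other way, so cyclopropyl gave the weakest result of the three groups tried. Any group other than cyclopropyl has so far given a lower number, and the branched isopropyl gave the lowest. On that basis a clearly lower number is expected for compound 4, on the order of a 19-fold lower number from compound 3 to compound 4 (1.27 log units; beyond the scatter). For the measured compounds named here, compound 4 is estimated at 400 nM, in the range 80 nM to 3000 nM, though only three compounds inform this and the outcome may differ.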

Compound 4, half-maximal inhibitory concentration: 360 nM
For compound 4 the middle estimate is 1.1-fold (0.05 log units) above the measured one, within the range that was stated.
By their numbers in this assay, from the lowest: compounds 2 and 4 (each within the scatter of the next); then compound 1; then compound 3.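

In this assay the step of a 21-fold lower number from compound 3 to compound 4 (1.32 log units; beyond the scatter) shows that a carbon ring on the amide-type nitrogen does not by itself give a high number: the weak result of compound 3 goes with cyclopropyl and does not extend to cyclopentyl. Cyclopentyl and isopropyl cannot be told apart here, given a 1.8-fold higher number from compound 2 to compound 4 (0.26 log units; within the scatter) and so the two groups share the low end of the series, while cyclopentyl in place of methyl gives a 6.9-fold lower number from compound 1 to compound 4 (0.84 log units; beyond the scatter) as a further gain over the smallest group. Nothing measured here explains why these groups differ.

As far as these compounds go, whether cyclobutyl or cyclohexyl would follow cyclopentyl or cyclopropyl remains open, as does the effect of an open chain such as n-butyl on this nitrogen. From the compounds shown here alone, all four compounds also keep the chloro and hydroxy groups, so what a fluoro or methoxy group would do in their place is unknown.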